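This account rests on a few compounds, and the source may have more. Where it says the series, first, only, none or still open, it means among the compounds named here.

Working notes on the series.

Compound 1 `CC1=CC[C@@H]([C@@](C)(O)CCCC(C)(C)NC(=S)NN)CC1` gives 26800 nM in a functional assay on PCO3 cells (Homo sapiens) for cytotoxicity, read by sulforhodamine B assay (a higher number here means a weaker inhibitor of growth, a lower number a stronger inhibitor of growth), compound 2 `CC1=CC[C@@H]([C@@](C)(O)CCCC(C)(C)NC(=S)N/N=C\c2ccccc2)CC1` gives 8470 nM, and compound 3 `CC1=CC[C@@H]([C@@](C)(O)CCCC(C)(C)NC(=S)N/N=C\c2cccc([N+](=O)[O-])c2)CC1` gives 5600 nM. Compound 2 thus stands second highest of the three numbers: the step of a 3.2-fold lower number from compound 1 to compound 2 (0.50 log units; beyond the scatter) is beyond the scatter, whereas the step of a 1.5-fold lower number from compound 2 to compound 3 (0.18 log units; within the scatter) is within it, so compound 2 and compound 3 cannot be ordered.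

The next compound, compound 4 `CC1=CC[C@@H]([C@@](C)(O)CCCC(C)(C)NC(=S)N/N=C\c2cccc(Cl)c2)CC1`, differs from compound 2 by chloro in place of hydrogen on an aromatic carbon. For the measured compounds named here, the step that bears on it is the one from compound 2 to compound 3, where a substituent entered on the same aromatic carbon of a six-membered aromatic ring of carbon only, meta to a large group, and the number moved by a 1.5-fold lower number from compound 2 to compound 3 (0.18 log units; within the scatter), within the scatter. Nothing in the series separates chloro from nitro at that position, so the expected step for compound 4 is small, a 1.3-fold lower number from compound 2 to compound 4 (0.11 log units; within the scatter), with no direction claimed beyond the scatter.

Compound 4 is therefore estimated at 6500 nM, with a range from 3000 nM to 14000 nM.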

Compound 4, concentration for 50% growth inhibition: 11300 nM
For compound 4 the middle estimate is 1.7-fold (0.24 log units) below the measured one; the range from low to high includes it.
By their numbers in this assay, from the lowest: compounds 3, 2 and 4 (each within the scatter of the next); then compound 1.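

At the aromatic carbon meta to a large group, chloro now stands alongside nitro in this assay: with a 1.3-fold higher number from compound 2 to compound 4 (0.13 log units; within the scatter) and a 2.0-fold higher number from compound 3 to compound 4 (0.30 log units; within the scatter), both steps lie within the scatter, so this position separates neither substituent from hydrogen nor the two from each other. The chlorinated aromatic group still keeps a difference from the parent compound, with a 2.4-fold lower number from compound 1 to compound 4 (0.38 log units; beyond the scatter) beyond the scatter, so the separation in this small set lies at the change from compound 1 and not at the ring substituent. No supporting data bear on why these numbers fall as they do.

As far as these compounds go, whether an amine or a carboxylic acid on the same aromatic carbon would move the number beyond the scatter stays open. Also open, from the compounds shown here alone, is whether a longer chain in place of the 3-chlorophenyl group would keep the difference from compound 1.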